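Methoxy in Place of Hydroxy at the Lowest Response

The source may report more compounds than this note shows. Statements on the series, on what has been measured and on what is new or still open speak of the compounds shown alone.

Measured so far:
Compound 1 `Cc1nn(-c2cccc3cc(Cc4cccc(C(F)(F)F)c4)sc23)cc1C(=O)NCCO`: 102% in a functional assay on CHO cells for agonist activity at G-protein coupled receptor 52 (Homo sapiens), read by AlphaScreen and cAMP accumulation, with a stated time of 30 min; a higher number here means a larger maximal response, a lower number a smaller maximal response
Compound 2 `O=C(NCCO)c1cnn(-c2cccc3cc(Cc4cccc(C(F)(F)F)c4)sc23)c1`: 73% in this assay
Compound 3 `COCCNC(=O)c1c(C)nn(-c2cccc3cc(Cc4cccc(C(F)(F)F)c4)sc23)c1C`: 104% in this assay

Compound 2 gives the lowest of the three numbers: the step of a number 29 percentage points lower from compound 1 to compound 2 (beyond the scatter) sets it apart from compound 1, and compound 3 lies higher still. Compound 4 `COCCNC(=O)c1cnn(-c2cccc3cc(Cc4cccc(C(F)(F)F)c4)sc23)c1` differs from compound 2 in one place: methyl in place of hydrogen on an oxygen on a saturated carbon. Among the measured compounds shown here, no measured step shows this change on its own. Compounds 1 and 3 differ in this place and in one more, and their two values sit within the scatter of each other, so the numbers give no direction for the change. For compound 4 the expected step is therefore a number 2 percentage points higher from compound 2 to compound 4 (within the scatter), within the scatter. Compound 4 is estimated to give 75%, between 58% and 92%.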

Compound 4, largest response reached (Emax), in percent of the reference or control that the assay uses in the G-protein coupled receptor 52 assay: 81%
For compound 4 the middle estimate is 6 percentage points below the measured one; the range from low to high includes it.
By their numbers in the G-protein coupled receptor 52 assay, from the lowest: compounds 2 and 4 (each within the scatter of the next); then compounds 1 and 3 (each within the scatter of the next).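

Among the compounds shown here, in the G-protein coupled receptor 52 assay, the change from 2-hydroxyethyl to 2-methoxyethyl, seen here on its own for the first time, gives a number 8 percentage points higher from compound 2 to compound 4 (within the scatter), so this response does not separate the two groups. In a physicochemical assay for solubility, read by HPLC, at pH 6.8 (on this read-out lower numbers stand for lower solubility and higher numbers for higher solubility), compound 2 gives < 0.09 ug/mL, which is a limit of the assay. In the physicochemical assay, compound 4 gives < 0.08 ug/mL, also a limit, and the step between the two cannot be read.

On these data alone, what an amine or a carboxylic acid in place of the hydroxy, or a longer chain on the oxygen, would give stays open. Also open, as far as these compounds go, is whether the same change reads alike on the core of compound 1.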